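The source may hold more compounds than are shown below. What is called first, only, known or untested is meant among the compounds shown, and "the series" means these compounds.

Notes on the series. In a toxicity assay on MT4 cells (Homo sapiens) for cytotoxicity, read by MTT assay, with a stated time of 5 days (on this read-out lower numbers stand for higher toxicity in this test and higher numbers for lower toxicity in this test), compound 1 `Cc1cnc(Nc2ccc(C#N)cc2)nc1Nc1c(F)cc(-c2ccoc2)cc1F` gives 4200 nM. Within the data shown here, compound 2 `Cc1cc(-c2cccc3cc[nH]c23)cc(C)c1Nc1ccnc(Nc2ccc(C#N)cc2)n1` gives 1000 nM in this assay, the lowest of the two numbers measured so far, with compound 1 standing clearly higher and the gap beyond the usual scatter. Compound 3 `Cc1cc(-c2cnc(C(F)(F)F)nc2)cc(C)c1Nc1ccnc(Nc2ccc(C#N)cc2)n1` differs from compound 2 in one place: 2-(trifluoromethyl)pyrimidin-5-yl in place of 1H-indol-7-yl on an aromatic carbon. Among the measured compounds shown here, no measured pair covers this change, so its direction is uncertain; a small shift toward a higher number, near the edge of the scatter, is the expectation, written as a 2.5-fold higher number from compound 2 to compound 3 (0.40 log units; beyond the scatter). Compound 3 is accordingly expected to give about 2500 nM in this assay, within 800 nM to 8000 nM.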

Compound 3, half-maximal cytotoxic concentration: 4900 nM
Compound 3: the middle estimate sits 2.0-fold (0.29 log units) below what was measured; the measured number falls inside the stated range.
By their numbers in this assay, from the lowest: compound 2; then compounds 1 and 3 (each within the scatter of the next).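

In this assay the aromatic carbon para to a large group responds to this exchange: 2-(trifluoromethyl)pyrimidin-5-yl in place of 1H-indol-7-yl gives a 4.9-fold higher number from compound 2 to compound 3 (0.69 log units; beyond the scatter) and moves toward lower toxicity in this test. The exchange removes the hydrogen-bond donor and adds hydrogen-bond acceptors while also changing the ring, and this single step cannot separate those differences. No measurement here explains the shift. As far as these compounds go, it remains open whether a simple phenyl ring or an amine at this carbon would give a number nearer compound 2 or compound 3.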